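The source may report more compounds than this note shows. Statements on the series, on what has been measured and on what is new or still open speak of the compounds shown alone.

Of the compounds shown here, three built on one shared core have been tested in an ADME assay on HCT-116 cells (Homo sapiens) for cytotoxicity, read by MTT assay, with a stated time of 72 h; on this read-out higher numbers stand for weaker inhibition and lower numbers for stronger inhibition. Compound 1 `CCc1cccc(NC(=O)c2cccc(/C=C3\CC(=O)N(c4ccccc4)C3=O)c2)c1` gives 81200 nM in this assay. For compound 2 `O=C(NCc1ccccc1)c1cccc(/C=C2\CC(=O)N(c3ccccc3)C2=O)c1` the read-out in this assay is only a limit, > 100000 nM. For compound 3 `COc1ccc(OC)c(NC(=O)c2cccc(/C=C3\CC(=O)N(c4ccccc4)C3=O)c2)c1` the same applies: in this assay compound 3 gives a limit, > 100000 nM. Compound 3 therefore stands at the upper edge of the numbers shown, a position summarised by the limit of > 100000 nM in this assay, at which 2 of the 3 values shown sit. The measured steps are small: an at least 1.2-fold higher number from compound 1 to compound 2 (0.09 log units; that floor lies within the scatter) and an at least 1.2-fold higher number from compound 1 to compound 3 (0.09 log units; that floor lies within the scatter), both resting on a limit, while a step that the two limits leave unreadable from compound 2 to compound 3.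

The account now follows compound 4 `CSc1cccc(NC(=O)c2cccc(/C=C3\CC(=O)N(c4ccccc4)C3=O)c2)c1`, which differs from compound 3 in one place: 3-(methylsulfanyl)phenyl in place of 2,5-dimethoxyphenyl on an amide-type nitrogen. Among the compounds with values here, no measured step connects these two groups directly; the nearest point of comparison is compound 1, whose 3-ethylphenyl group also sits on an amide-type nitrogen and gives 81200 nM in this assay. Because every shift seen so far is an at least 1.2-fold higher number from compound 1 to compound 3 (0.09 log units; that floor lies within the scatter) or smaller, no step beyond the scatter is expected in this assay in either direction. The estimated step is a number no higher from compound 3 to compound 4 (the limit leaves the size open). Compound 4 is thus expected to give 100000 nM in this assay, within a range from 50000 nM to 200000 nM, with a fair chance that only a limit is reported.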

Compound 4, half-maximal inhibitory concentration: 65200 nM
Estimate against measurement, compound 4: 1.5-fold (0.19 log units) above; low and high end bracket the measured number.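

In this assay, compound 4 gives a number rather than a limit, so compound 1 and compound 4 now provide a pair of readable values for substituted phenyl groups on the amide-type nitrogen. Methylsulfanyl in place of ethyl on the aromatic carbon gives a 1.2-fold lower number from compound 1 to compound 4 (0.10 log units; within the scatter), so these two groups cannot be told apart on this read-out. Against the other two compounds, the result is an at least 1.5-fold lower number from compound 3 to compound 4 (0.18 log units; that floor lies within the scatter) and an at least 1.5-fold lower number from compound 2 to compound 4 (0.18 log units; that floor lies within the scatter); each of these is only a floor resting on a limit of the assay, and the true size of neither step can be read: the limit of > 100000 nM in this assay, at which 2 of the 4 values shown sit.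

The compounds shown leave open whether any group on the amide-type nitrogen gives a step beyond the scatter, and how far compound 2 and compound 3 actually lie from compound 4. They also leave open what an amine or a carboxylic acid in place of methylsulfanyl on the aromatic carbon would give in this assay.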